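Swapping the Benzylic Substituent in a Deubiquitinase Inhibitor Series

A few compounds are considered here, and "the series" means these few. Any claim that something is new, unique, unknown or untested is made for them only; others in the source may bear on it.

Three compounds built on one shared core were tested in an assay on isolated protein for inhibition of ubiquitin carboxyl-terminal hydrolase 7 (Homo sapiens), with stated times of 30 min and 2 h; on this read-out higher numbers stand for weaker inhibition and lower numbers for stronger inhibition. Compound 1 `Cn1nc2c(=O)n(CC3(O)CCN(Cc4ccc(-c5ccco5)cc4Cl)CC3)cnc2c1-c1ccc(CO)cc1` gives 42.5 nM, compound 2 `CC(=O)NCc1ccc(-c2c3ncn(CC4(O)CCN(Cc5ccc(-c6ccco6)cc5Cl)CC4)c(=O)c3nn2C)cc1` gives 46.1 nM, and compound 3 `CC(C)NCc1ccc(-c2c3ncn(CC4(O)CCN(Cc5ccc(-c6ccco6)cc5Cl)CC4)c(=O)c3nn2C)cc1` gives 29.1 nM. Compound 3 has the lowest of these three numbers, yet the steps of a 1.5-fold lower number from compound 1 to compound 3 (0.16 log units; within the scatter) and a 1.6-fold lower number from compound 2 to compound 3 (0.20 log units; within the scatter) both lie within the scatter, so the three cannot be ranked against each other. Compound 4 `Cn1nc2c(=O)n(CC3(O)CCN(Cc4ccc(-c5ccco5)cc4Cl)CC3)cnc2c1-c1ccc(C(=N)N)cc1` carries the change (a group of 3 heavy atoms (1 carbon, 2 nitrogen; no ring) in place of a group of 5 heavy atoms (4 carbon, 1 nitrogen; no ring), on an aromatic carbon). The two steps just named bear on it. Each exchanged the group at this same position, and each stayed small. The expected outcome is therefore a 1.4-fold higher number from compound 3 to compound 4 (0.14 log units; within the scatter), a change within the scatter with no clear direction. Compound 4 is estimated at 40 nM, between 15 nM and 110 nM.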

Compound 4, half-maximal inhibitory concentration: 87.5 nM
Compound 4: middle estimate off by 2.2-fold (0.34 log units), on the low side, within the range that was stated.
By their numbers in this assay, from the lowest: compounds 3, 1, 2 and 4 (each within the scatter of the next, the first and the last beyond it).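

Both a 3.0-fold higher number from compound 3 to compound 4 (0.48 log units; beyond the scatter) and a 2.1-fold higher number from compound 1 to compound 4 (0.31 log units; beyond the scatter) lie beyond the scatter in this assay, whereas a 1.9-fold higher number from compound 2 to compound 4 (0.28 log units; within the scatter) stays within it. So this position is not wholly indifferent to its group: the earlier exchanges here all stayed within the scatter, while the group of 3 heavy atoms in compound 4 produces the first modest shifts. No available measurement accounts for these shifts.

The compounds shown leave open how a carboxylic acid or a plain aminomethyl group on this aromatic carbon would read in this assay. They also leave open whether a longer chain carrying the same group of 3 heavy atoms would stay close to compound 4.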